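The source may report more compounds than this note shows. Statements on the series, on what has been measured and on what is new or still open speak of the compounds shown alone.

Measured so far:
compound 1 `O=C(C=CNc1cc(-c2ccccc2)nn1-c1ccccc1)c1ccc(F)cc1` — 59900 nM
compound 2 `Cc1ccc(C(=O)C=CNc2cc(-c3ccccc3)nn2-c2ccccc2)cc1` — 7320 nM

Compound 2 stands lowest of the two numbers in a functional assay on HepG2 cells (Homo sapiens) for inhibition, read by MTT assay, with a stated time of 48 h; on this read-out lower numbers stand for stronger inhibition and higher numbers for weaker inhibition; its nearest neighbour is compound 1, and the step of an 8.2-fold lower number from compound 1 to compound 2 (0.91 log units; beyond the scatter) is beyond the scatter.

Compound 3 `O=C(C=CNc1cc(-c2ccccc2)nn1-c1ccccc1)c1ccc(Br)cc1` is not yet measured. It differs from compound 2 by bromo in place of methyl on an aromatic carbon.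

Among the measured compounds shown here, no measured step swaps a methyl for a bromo. For the measured compounds named here, the only step that bears on this position is the fluoro-to-methyl change, an 8.2-fold lower number from compound 1 to compound 2 (0.91 log units; beyond the scatter), which shows that the substituent para to the carbonyl-bearing group moves the number a good deal. Bromo is a halogen like the fluoro of compound 1 yet a single heavy atom like the methyl of compound 2, so the number for compound 3 is expected to fall between the two, closer to compound 2, giving an estimated step of a 1.8-fold higher number from compound 2 to compound 3 (0.25 log units; within the scatter) that may sit near the scatter.

Compound 3 is therefore estimated at 13000 nM in this assay, within 3500 nM to 48000 nM.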

Compound 3, half-maximal inhibitory concentration: 8810 nM
The estimate for compound 3 lay 1.5-fold (0.17 log units) above the measured number; the measured number falls inside the stated range.
By their numbers in this assay, from the lowest: compounds 2 and 3 (each within the scatter of the next); then compound 1.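

In this assay, bromo in place of methyl on an aromatic carbon, para to a large group, leaves the number within the scatter (a 1.2-fold higher number from compound 2 to compound 3 (0.08 log units; within the scatter)), so this exchange does not separate the two groups, which the earlier pair could not show. Bromo in place of fluoro gives a clear change (a 6.8-fold lower number from compound 1 to compound 3 (0.83 log units; beyond the scatter)), so the gain from leaving fluoro is not confined to methyl, and halogens do not read as one class here, with compound 1 and compound 3 standing apart. Nothing measured here accounts for why fluoro differs from the other two groups.

Open, on these data alone, is how an amine, a carboxylic acid, a methoxy group or a longer alkyl chain would read at this position, and how the parent ring with hydrogen there compares. Also open, as far as these compounds go, is whether the same order of groups would hold elsewhere on the shared core.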